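This account rests on a few compounds, and the source may have more. Where it says the series, first, only, none or still open, it means among the compounds named here.

Among the measured compounds shown here, in a functional assay on MCF7 cells (Homo sapiens) (a higher number here means a weaker inhibitor of growth, a lower number a stronger inhibitor of growth), compound 1 (`O=S(=O)(/C=C/c1ccc(F)cc1)Cc1ccc(Nc2ncnc3ccccc23)cc1`) gives 16000 nM, the lower of the two numbers measured so far, which makes it the stronger growth inhibitor of the pair. Compound 2 (`O=S(=O)(/C=C/c1ccc(Cl)cc1)Cc1ccc(Nc2ncnc3ccccc23)cc1`) gives 52000 nM. Compound 3 (`O=S(=O)(/C=C/c1ccc(F)cc1Cl)Cc1ccc(Nc2ncnc3ccccc23)cc1`) has not yet been measured. It differs from compound 1 by a single change, chloro in place of hydrogen on an aromatic carbon, ortho to a large group and meta to a fluoro group, turning 4-fluorophenyl into 2-chloro-4-fluorophenyl. For the measured compounds named here, no measured compound carries chloro at that place, and compound 3 keeps the fluoro group, so the evidence is thin. Going by the values given here, only one measured step bears on the change, and only loosely: with chloro in place of fluoro on an aromatic carbon, it is a 3.3-fold higher number from compound 1 to compound 2 (0.51 log units; beyond the scatter), so a modest move toward a higher number, no larger than that step, is expected in this assay. The estimated step is a 1.6-fold higher number from compound 1 to compound 3 (0.19 log units; within the scatter). For compound 3 the expected value is 25000 nM, with an estimated range of 8000 nM to 75000 nM.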

Compound 3, concentration for 50% growth inhibition: 21000 nM
For compound 3 the middle estimate is 1.2-fold (0.08 log units) above the measured one; the range from low to high includes it.
By their numbers in this assay, from the lowest: compounds 1 and 3 (each within the scatter of the next); then compound 2.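

Chloro in place of hydrogen, ortho to a large group and meta to a fluoro group, gives a 1.3-fold higher number from compound 1 to compound 3 (0.12 log units; within the scatter) in this assay and so leaves compound 1 and compound 3 indistinguishable, which shows that this position can carry chloro without a step beyond the scatter. Compound 3 also carries chloro yet gives a 2.5-fold lower number from compound 2 to compound 3 (0.39 log units; beyond the scatter) and so parts from compound 2, which means that a chloro group on this aryl ring does not by itself go with the higher number; among these three compounds, the two that keep the fluoro group, compound 1 and compound 3, both lie below compound 2, and none goes against this. No measurement given here explains these differences.

On these data alone, it remains open whether a methyl, a methoxy or an amine at the same place would also stay within the scatter of compound 1, or whether a larger step would appear. As far as these compounds go, it also remains open whether chloro at this place would behave alike on the 4-chlorophenyl group of compound 2.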